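A few compounds are considered here, and "the series" means these few. Any claim that something is new, unique, unknown or untested is made for them only; others in the source may bear on it.

In an assay on HL-60 cells for agonist activity at vitamin D3 receptor (Homo sapiens), read by microscopy, with a stated time of 96 h (on this read-out lower numbers stand for an effect already at smaller amounts and higher numbers for an effect only at larger amounts of compound), the three measured compounds stand as follows:
compound 1 `CCn1c(C(=O)NCC(OC)OC)ccc1C(CC)(CC)c1ccc(OCC(=O)C(C)(C)C)c(C)c1` gives 130 nM;
compound 2 `C#CCNC(=O)c1ccc(C(CC)(CC)c2ccc(OCC(O)C(C)(C)C)c(C)c2)n1CC` gives 240 nM;
compound 3 `CCn1c(C(=O)N(C)CC(=O)O)ccc1C(CC)(CC)c1ccc(OCC(O)C(C)(C)C)c(C)c1` gives 740 nM.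

Compound 1 has the lowest number of the three: compound 2 lies within the scatter of it, while compound 3 lies beyond it. Compound 4 `CCOc1ccc(NC(=O)c2ccc(C(CC)(CC)c3ccc(OCC(=O)C(C)(C)C)c(C)c3)n2CC)cc1` differs from compound 1 by 4-ethoxyphenyl in place of 2,2-dimethoxyethyl on an amide-type nitrogen. Within the data shown here, the only measured step touching the amide substituent is a 3.1-fold higher number from compound 2 to compound 3 (0.49 log units; beyond the scatter), a modest change made with a different pair of groups, so it offers no direct guide to this exchange. The step expected in this assay is therefore a 1.2-fold higher number from compound 1 to compound 4 (0.09 log units; within the scatter), with no firm direction. Compound 4 is estimated at 160 nM, with a range running from 50 nM to 550 nM.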

Compound 4, half-maximal effective concentration: > 50000 nM
Compound 4: no number, only a limit; the forecaster's own chance of this, stated with the estimate: 5%; middle value at least 310-fold (2.49 log units) away from the limit.
By their numbers in this assay, from the lowest: compounds 1 and 2 (each within the scatter of the next); then compound 3. At a limit, above all of these: compound 4.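

In this assay the amide-type nitrogen turns out not to tolerate every substituent: 4-ethoxyphenyl in place of 2,2-dimethoxyethyl gives an at least 380-fold higher number from compound 1 to compound 4 (2.58 log units; beyond the scatter), whereas the earlier change at this place gave only a 3.1-fold higher number from compound 2 to compound 3 (0.49 log units; beyond the scatter). For compound 4 the reading > 50000 nM is a limit of the assay, not a number: the limit of > 50000 nM in this assay, at which 1 of the 4 values shown sits.

The compounds shown do not separate the aromatic ring from its ethoxy group as the source of this loss. An unsubstituted phenyl or a cyclohexyl group on the same nitrogen would bear on that question.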